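Trifluoromethyl for Methyl on the Pendant Ring

The source may hold more compounds than are shown below. What is called first, only, known or untested is meant among the compounds shown, and "the series" means these compounds.

Measured compounds:
- compound 1, `CCC(CCOC)n1c(OC)nc2c(-c3ccc(OC(F)(F)F)cc3Cl)ccnc21`, gives 1.9 nM
- compound 2, `CCCC(C)n1c(CC)nc2c(-c3ccc(OC)cc3C)ccnc21`, gives 0.8 nM
- compound 3, `CCCC(C)n1c(CC)nc2c(-c3ccc(/C(C)=N\OC)cc3Cl)ccnc21`, gives 2.3 nM

In an assay for binding affinity to Corticotropin releasing factor receptor (Rattus norvegicus) (on this read-out higher numbers stand for weaker inhibition and lower numbers for stronger inhibition), compound 2 has the lowest number of the three, and its gaps to compound 1 and to compound 3 both lie beyond the usual scatter, so on this read-out compound 2 is the strongest binder shown. Compound 4, `CCCC(C)n1c(CC)nc2c(-c3ccc(OC)cc3C(F)(F)F)ccnc21`, is not yet measured. It differs from compound 2 in one place: trifluoromethyl in place of methyl on an aromatic carbon, ortho to a large group and meta to a methoxy group. Among the measured compounds shown here, no measured pair shows this exact exchange, so the expectation rests on compound 2 alone. A small weakening is expected, a step of a 1.9-fold higher number from compound 2 to compound 4 (0.27 log units; within the scatter) that may still fall within the scatter. Compound 4 is expected to give about 1.5 nM, in a range from 0.5 nM to 5 nM.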

Compound 4, inhibition constant: 0.74 nM
The estimate for compound 4 lay 2.0-fold (0.31 log units) above the measured number; the range from low to high includes it.
By their numbers in this assay, from the lowest: compounds 4 and 2 (each within the scatter of the next); then compounds 1 and 3 (each within the scatter of the next).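

In this assay, trifluoromethyl in place of methyl on an aromatic carbon gives a 1.1-fold lower number from compound 2 to compound 4 (0.03 log units; within the scatter), so this position, ortho to a large group and meta to a methoxy group, tolerates the larger group without a change that stands out from the scatter. Among the compounds shown here, this is the first direct reading of a single change here, as the earlier compounds offered no such pair. Nothing available explains why the affinity holds.

Still open, going by these compounds, is how an amine or a carboxylic acid would fare at this position. Also open, on these data alone, is whether the same exchange would hold up in the other compounds, which carry different groups elsewhere.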